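Isopropyl urea in place of aryl urea in the series

The source may hold more compounds than are shown below. What is called first, only, known or untested is meant among the compounds shown, and "the series" means these compounds.

Measured compounds:
compound 1 `Cn1nc(COc2cccc(F)c2)c2c1CCN(C(=O)Nc1ccc(Cl)cc1)C2` — 6600 nM
compound 2 `Cn1nc(C(=O)O)c2c1CCN(C(=O)Nc1ccc(Cl)cc1)C2` — > 10000 nM
compound 3 `Cn1nc(COc2cc(F)cc(F)c2)c2c1CCN(C(=O)Nc1ccc(Br)cc1)C2` — 3300 nM

In an assay on cells for inhibition of Pendrin (Mus musculus), read by fluorescence, with a stated time of 10 min (on this read-out lower numbers stand for stronger inhibition and higher numbers for weaker inhibition), compound 3 gives 3300 nM, the lower of the two numbers shown, although its gap to compound 1 lies within the scatter. Compound 1 gives 6600 nM in this assay. For compound 2 this assay reports only a limit, > 10000 nM, at which one of the three values sits (the limit of > 10000 nM in this assay, at which 1 of the 3 values shown sits).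

For the measured compounds named here, the one measured step, an at least 1.5-fold higher number from compound 1 to compound 2 (0.18 log units; that floor lies within the scatter), concerns the aromatic carbon of the core and not the urea nitrogen, so it bears only loosely on the present change. Compound 4 `CC(C)NC(=O)N1CCc2c(c(COc3cc(F)cc(F)c3)nn2C)C1` differs from compound 3 by isopropyl in place of 4-bromophenyl on an amide-type nitrogen. Going by the values given here, no measured pair shows what the urea substituent contributes, so the expectation rests on the loss of the aromatic ring alone and on the observation that every change so far has weakened or left unchanged the read-out. A weakening is therefore expected, estimated as a 2.4-fold higher number from compound 3 to compound 4 (0.38 log units; beyond the scatter). Compound 4 is expected to give 8000 nM in this assay, within 2500 nM to 25000 nM, with a real chance that only a limit is reported.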

Compound 4, half-maximal inhibitory concentration: > 10000 nM
Compound 4: only a limit was reported; the forecaster's own chance of this, stated with the estimate: 40%; middle value at least 1.2-fold (0.09 log units) away from the limit.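

For the compounds shown here, this is the only measured pair that changes the group on the amide-type nitrogen, and in this assay isopropyl in place of 4-bromophenyl gives an at least 3.0-fold higher number from compound 3 to compound 4 (0.48 log units; beyond the scatter). From the compounds shown here alone, compound 4 gives > 10000 nM, which is a limit of the assay, so this step is a floor and its full size stays unknown. Even as a floor it lies beyond the scatter, unlike the step at the aromatic carbon, and limits now make up a larger share of the series: the limit of > 10000 nM in this assay, at which 2 of the 4 values shown sit.

The compounds shown leave open whether the aromatic ring or the bromine carries this difference; phenyl or cyclohexyl on the same nitrogen would separate the two. Compound 1 and compound 3 differ in more than one place, so the halogen on the aryl urea cannot be judged separately from the fluorine on the phenoxy group.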